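Swapping Fluoro for Trifluoromethoxy at the Styryl End

A few compounds are considered here, and "the series" means these few. Any claim that something is new, unique, unknown or untested is made for them only; others in the source may bear on it.

Of the compounds shown here, three built on one shared core have been measured in a functional assay on HeLa cells (Homo sapiens) for antiproliferative activity, read by MTT assay, with a stated time of 12 h; on this read-out lower numbers stand for stronger inhibition and higher numbers for weaker inhibition. Compound 1 `COc1cc(OC)c2c(=O)cc(/C=C/c3ccccc3)oc2c1` gives 10100 nM. Compound 2 `COc1cc(OC)c2c(=O)cc(/C=C/c3ccc(Cl)cc3)oc2c1` gives 14200 nM, and compound 3 `COc1cc(OC)c2c(=O)cc(/C=C/c3ccc(F)cc3)oc2c1` gives 14200 nM. Compound 3 thus sits level with compound 2, and the step of a 1.4-fold higher number from compound 1 to compound 3 (0.15 log units; within the scatter) shows that none of the three is separated from the others beyond the scatter. Compound 4 `COc1cc(OC)c2c(=O)cc(/C=C/c3ccc(OC(F)(F)F)cc3)oc2c1` differs from compound 3 by trifluoromethoxy in place of fluoro on an aromatic carbon. The steps that touch this same position are a 1.4-fold higher number from compound 1 to compound 2 (0.15 log units; within the scatter), a 1.4-fold higher number from compound 1 to compound 3 (0.15 log units; within the scatter) and no change at the digits printed from compound 2 to compound 3 (within the scatter), all within the scatter, so no change beyond the scatter is expected in this assay. The expected step is therefore a 1.0-fold lower number from compound 3 to compound 4 (0.01 log units; within the scatter). Compound 4 is estimated at 14000 nM, with a range from 6000 nM to 35000 nM.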

Compound 4, half-maximal inhibitory concentration: > 40000 nM
Compound 4 ended at the assay's limit (the forecaster's own chance of this, stated with the estimate: 5%); at least 2.8-fold (0.45 log units) between middle value and limit.
By their numbers in this assay, from the lowest: compounds 1, 2 and 3 (each within the scatter of the next). At a limit, above all of these: compound 4.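

Hydrogen, chloro and fluoro at this position gave numbers within the scatter of one another, but trifluoromethoxy moves the read-out beyond the scatter towards weaker inhibition: an at least 2.8-fold higher number from compound 3 to compound 4 (0.44 log units; beyond the scatter), an at least 2.8-fold higher number from compound 2 to compound 4 (0.44 log units; beyond the scatter) and an at least 3.9-fold higher number from compound 1 to compound 4 (0.59 log units; beyond the scatter). Compound 4 stands at a limit of this assay, not at a number: the limit of > 40000 nM in this assay, at which 1 of the 4 values shown sits. Going by these compounds, the position therefore does respond to the group placed on it, though the full size of these steps stays unknown.

Open, on these data alone, is how methoxy, trifluoromethyl, an amine or a carboxylic acid would read at this position. The compounds shown also cannot tell whether the oxygen or the fluorines of trifluoromethoxy go with the weaker inhibition.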